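The source may hold more compounds than are shown below. What is called first, only, known or untested is meant among the compounds shown, and "the series" means these compounds.

Series notes, measured in an assay for binding affinity to Adrenergic receptor alpha-1 (Rattus norvegicus); on this read-out higher numbers stand for weaker inhibition and lower numbers for stronger inhibition:

compound 1 `COc1cc2nc(N3CCN(C(=O)/C=C/c4cccc(F)c4)CC3)nc(N)c2cc1OC` — compound 1 gives 20.9 nM
compound 2 `COc1cc2nc(N3CCN(C(=O)COc4ccccc4)CC3)nc(N)c2cc1OC` — compound 2 gives 12.6 nM
compound 3 `COc1cc2nc(N3CCN(/C(S)=N/c4ccccc4)CC3)nc(N)c2cc1OC` — compound 3 gives 0.00692 nM

Compound 3 holds the lowest number of the three, well clear of the other two: the step of a 1800-fold lower number from compound 2 to compound 3 (3.26 log units; beyond the scatter) is large and beyond the scatter, and the gap to compound 1 is wider still. By contrast, the step of a 1.7-fold lower number from compound 1 to compound 2 (0.22 log units; within the scatter), which swaps the whole acyl substituent on the ring nitrogen, stays within the scatter.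

The next compound, compound 4 `COc1cc2nc(N3CCN(/C(S)=N/c4ccc(N=[N+]=[N-])cc4)CC3)nc(N)c2cc1OC`, keeps the thiourea-type arm of compound 3 and alters only the outer aryl ring: azido in place of hydrogen on an aromatic carbon. Neither measured step speaks to this kind of change. Among the measured compounds shown here, the step from compound 1 to compound 2 exchanges one aryl-bearing arm for another, and the step from compound 2 to compound 3 replaces the arm entirely; no pair differs by a single substituent on an aryl ring that is otherwise left alone. There is therefore no measured basis for predicting a shift in this assay, and the working assumption is a step of a 1.3-fold higher number from compound 3 to compound 4 (0.11 log units; within the scatter), within the scatter, so that compound 4 is expected near compound 3. The estimate for compound 4 in this assay is 0.009 nM, with a range from 0.002 nM to 0.05 nM.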

Compound 4, half-maximal inhibitory concentration: 20 nM
The estimate for compound 4 lay 2200-fold (3.35 log units) below the measured number; the measured number lies above the stated range.
By their numbers in this assay, from the lowest: compound 3; then compounds 2, 4 and 1 (each within the scatter of the next).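

In this assay, the thiourea-type arm does not by itself carry the very low number of compound 3: with that arm and the shared core unchanged, azido in place of hydrogen gives a 2900-fold higher number from compound 3 to compound 4 (3.46 log units; beyond the scatter). Among the compounds shown here, the earlier steps changed the whole arm on the ring nitrogen, so this is the first sign that the outer phenyl ring matters, and that a single substituent on an aromatic carbon, para to a large group, can move the number by a large margin. No measurement here accounts for this loss, so the shift stands as an observation without an explanation.

The compounds shown cannot separate an effect specific to azido from one that any substituent at this place would produce, and a fluorine, a methoxy group or an amine on the same aromatic carbon would help to draw that line. On these data alone, with only phenyl and 4-azidophenyl to compare, it also remains open whether the very low number of compound 3 depends on an unsubstituted ring or would survive some smaller replacement for hydrogen.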